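This account rests on a few compounds, and the source may have more. Where it says the series, first, only, none or still open, it means among the compounds named here.

Measured compounds:
Compound 1, `O=S(=O)(CCC(F)=C(F)F)c1nc2ccc(OC(F)F)cc2[nH]1`, gives in a functional assay on SH-SY5Y cells (Homo sapiens) for cytotoxicity, read by MTT assay, with a stated time of 48 h (on this read-out higher numbers stand for weaker inhibition and lower numbers for stronger inhibition), only a limit, > 120000 nM.
Compound 2, `FC(F)=C(F)CCSc1nc2ccccc2[nH]1`, gives in this assay only a limit, > 120000 nM.
Compound 3, `FC(F)=C(F)CCSc1ncc(Cl)s1`, gives in this assay only a limit, > 120000 nM.

Compound 2 cannot be placed in any order among these three, since none of them yields a number: all three stop at the same point, which is the limit of > 120000 nM in this assay, at which 3 of the 3 values shown sit. Nothing in this set therefore separates compound 2 from compound 1 or compound 3 in this assay.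

Compound 4, `FC(F)=C(F)CCSc1nc2ccc(OC(F)F)cc2[nH]1`, has not yet been measured in this assay. It differs from compound 2 in one place: difluoromethoxy in place of hydrogen on an aromatic carbon. Compound 1 already carries that same difluoromethoxy group on the same kind of fused ring and also reaches only the limit in this assay, so the set gives no sign that this group brings measurable cytotoxicity.

The step from compound 2 to compound 4 is therefore expected to be a step that the limit leaves unreadable from compound 2 to compound 4, which means no change beyond the usual scatter. Compound 4 is estimated at 150000 nM in this assay, with a range from 100000 nM to 400000 nM, and it is expected that the assay will again report only a limit rather than a number.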

Compound 4, half-maximal inhibitory concentration: > 120000 nM
Compound 4 was reported as a limit (the forecaster's own chance of this, stated with the estimate: 90%); the middle value lies beyond the limit too.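

In this assay compound 4 and compound 2 both stop at a limit, so no step can be read for difluoromethoxy in place of hydrogen on an aromatic carbon: the limit of > 120000 nM in this assay, at which 4 of the 4 values shown sit. The compounds shown leave open at what concentration, if any, each would reach half-maximal inhibition, and whether difluoromethoxy would then make any difference.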